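A few compounds are considered here, and "the series" means these few. Any claim that something is new, unique, unknown or untested is made for them only; others in the source may bear on it.

Measured so far:
- compound 1 `Oc1ccc(-c2nn3c(NC4CCCC4)nccc3c2-c2ccnc(NC3CCCC3)n2)cc1`; in an ADME assay on Vero cells (Chlorocebus sabaeus) for cytotoxicity (on this read-out lower numbers stand for higher toxicity in this test and higher numbers for lower toxicity in this test), compound 1 gives 27000 nM
- compound 2 `CC(C)COc1ccc(-c2nn3c(NC4CCCC4)nccc3c2-c2ccnc(NC3CCCC3)n2)cc1`; compound 2 gives > 40000 nM, which is a limit of the test and not a number
- compound 3 `c1cc(-c2c(-c3ccc(OCC4CC4)cc3)nn3c(NC4CCCC4)nccc23)nc(NC2CCCC2)n1`; compound 3 gives > 40000 nM, likewise a limit of the test

Compound 3 therefore stands at the ceiling of this assay, where the limit of > 40000 nM in this assay, at which 2 of the 3 values shown sit, holds; no number is known for it. The two readable steps are an at least 1.4-fold higher number from compound 1 to compound 2 (0.17 log units; that floor lies within the scatter) and an at least 1.4-fold higher number from compound 1 to compound 3 (0.17 log units; that floor lies within the scatter); both reach only the limit, and their floors lie within the scatter. The step that the two limits leave unreadable from compound 2 to compound 3 cannot be sized from two limits.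

Compound 4 `COCCOc1ccc(-c2nn3c(NC4CCCC4)nccc3c2-c2ccnc(NC3CCCC3)n2)cc1` differs from compound 3 by methoxymethyl in place of cyclopropyl on a saturated chain carbon bound to an oxygen on an aromatic ring. Going by the values given here, no measured pair shows this exchange. What bears on it is that both ether substituents in compound 2 and compound 3 sit at the same limit, while only the free hydroxyl of compound 1 gave a number; a further ether chain of the same size is expected to behave like these two. The step of a number no higher from compound 3 to compound 4 (the limit leaves the size open) is therefore expected to be none beyond the scatter, with compound 4 most likely again reported as a limit.

For compound 4 the expected value in this assay is 40000 nM, with a range from 20000 nM to 80000 nM.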

Compound 4, half-maximal cytotoxic concentration: > 40000 nM
Compound 4 ended at the assay's limit; the forecaster's own chance of this, stated with the estimate: 60%; the middle value lies on the limit itself.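

In this assay compound 4 gives > 40000 nM, which is a limit of the test and not a number. At this place, on a saturated chain carbon bound to an oxygen on an aromatic ring, methoxymethyl with its hydrogen-bond acceptor now stands where cyclopropyl stood, and the value stays at the limit, so neither the three-membered ring nor an all-carbon chain is needed to reach it. The steps among compound 2, compound 3 and compound 4 cannot be read, and the only readable new step is an at least 1.4-fold higher number from compound 1 to compound 4 (0.17 log units; that floor lies within the scatter), which leaves the hydroxyl and ether compounds unseparated beyond the scatter, with most of the set at the ceiling: the limit of > 40000 nM in this assay, at which 3 of the 4 values shown sit.

Going by these compounds, how far compound 2, compound 3 and compound 4 lie past the limit stays open, and so does whether their order differs at all. Also open, on these data alone, is whether a chain ending in an amine or a carboxylic acid, or a longer chain, at this place would bring the value down to a readable number in this assay.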